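Aminomethyl for chloro on the phenyl-bearing core

A few compounds are considered here, and "the series" means these few. Any claim that something is new, unique, unknown or untested is made for them only; others in the source may bear on it.

Measured in an assay on Flp-In-CHO cells for binding affinity to adenosine receptor A3 (Homo sapiens), read by NanoBRET; on this read-out lower numbers stand for stronger inhibition and higher numbers for weaker inhibition:
compound 1 `COc1cc(Nc2nc(Cl)cc3c(C(C)C)n[nH]c23)cc(OC)c1OC`: 631 nM
compound 2 `COc1cc(Nc2nc(C#N)cc3c(C(C)C)n[nH]c23)cc(OC)c1OC`: 603 nM
compound 3 `COc1cc(Nc2nc(Cl)cc3c(-c4ccccc4)n[nH]c23)cc(OC)c1OC`: 55 nM

Compound 3 gives the lowest number of the three; compound 2 and compound 1 sit far higher, both beyond the scatter, and their two values are within the scatter of each other. The step of an 11-fold lower number from compound 1 to compound 3 (1.06 log units; beyond the scatter) is the only large one seen.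

Compound 4 `COc1cc(Nc2nc(CN)cc3c(-c4ccccc4)n[nH]c23)cc(OC)c1OC` differs from compound 3 by aminomethyl in place of chloro on an aromatic carbon.

Going by the values given here, the one step at this position is a 1.0-fold lower number from compound 1 to compound 2 (0.02 log units; within the scatter), made on the isopropyl-bearing core, where chloro and cyano give the same number. Among the compounds with values here, no measured step exchanges chloro for aminomethyl, and no step at this position exists on the phenyl-bearing core, so the bearing of the change on compound 4 is uncertain. A modest step in this assay, if any, is expected; with the introduction of a hydrogen-bond donor, a somewhat higher number is taken as the more likely direction, giving an expected 1.8-fold higher number from compound 3 to compound 4 (0.26 log units; within the scatter).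

Compound 4 is estimated at 100 nM, within 30 nM to 400 nM.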

Compound 4, inhibition constant: 132 nM
The estimate for compound 4 lay 1.3-fold (0.12 log units) below the measured number; the measured number falls inside the stated range.
By their numbers in this assay, from the lowest: compound 3; then compound 4; then compounds 2 and 1 (each within the scatter of the next).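

In this assay, the step of a 2.4-fold higher number from compound 3 to compound 4 (0.38 log units; beyond the scatter) shows that this position, on an aromatic carbon next to the ring nitrogen, can move the number on the core of compound 3, though only modestly. Going by these compounds alone, the earlier step at this position, a 1.0-fold lower number from compound 1 to compound 2 (0.02 log units; within the scatter), was made on the core of compound 1 and showed no separation between chloro and cyano, so aminomethyl in place of chloro gives the first change beyond the scatter here. Compound 4 still gives 132 nM with aminomethyl at this place, and no measurement at hand explains the step.

As far as these compounds go, whether cyano on the core of compound 3 would match chloro, as it does on the core of compound 1, remains open, as does the effect of aminomethyl on the core of compound 1. A methyl, a hydroxymethyl or a longer aminoethyl chain at this place would help separate the contribution of the amine from that of the added carbon.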